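Adding a chlorine to an eight-carbon biguanide

A few compounds are considered here, and "the series" means these few. Any claim that something is new, unique, unknown or untested is made for them only; others in the source may bear on it.

Three compounds share a biguanide core carrying an aromatic ring and an alkyl chain, and all three were measured in a physicochemical assay for lipophilicity, in phosphate buffer, measured as octanol-water partition, at pH 11.5; a lower number here means a more polar compound, a higher number a more lipophilic compound. Compound 1, `CCCCCCCCCCNC(=N)NC(=N)Nc1ccc(Cl)cc1`, gives 6.13. Compound 2, `CNC(=N)NC(=N)Nc1ccc(Cl)cc1`, gives 1.58. Compound 3, `CCCCCCCCNC(=N)NC(=N)Nc1ccccc1`, gives 4.43, which places it second highest of the three: compound 1 lies higher by a margin beyond the scatter, and compound 2 lies lower by a still larger margin, also beyond the scatter.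

The next compound, compound 4, `CCCCCCCCNC(=N)NC(=N)Nc1ccc(Cl)cc1`, has not yet been measured in this assay. It differs from compound 3 in one place: chloro in place of hydrogen on an aromatic carbon. The chloro enters on an aromatic carbon of a six-membered aromatic ring of carbon only. Among the compounds with values here, no pair of measured compounds differs by exactly this change, so no measured step settles its size. Still, compound 1, which carries both a chloro and a longer chain, stands at 6.13, well above compound 3 at 4.43, and this is consistent with an upward step.

For compound 4 an upward step of a number 0.67 log units higher from compound 3 to compound 4 (beyond the scatter) is expected, beyond the scatter but smaller than the gap to compound 1. Compound 4 is therefore estimated at 5.1, likely between 4.6 and 5.7.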

Compound 4, partition coefficient: 5.13
Estimate against measurement, compound 4: 0.03 log units below, and the stated range covers the measured number.
By their numbers in this assay, from the lowest: compound 2; then compound 3; then compound 4; then compound 1.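

In this assay, chloro in place of hydrogen on an aromatic carbon, para to a large group, now has a measured size: the change gives a number 0.70 log units higher from compound 3 to compound 4 (beyond the scatter) with nothing else altered. Compound 4 also links the two other chlorinated compounds, so the chain can be read on its own while the chloro stays fixed: heptyl in place of hydrogen on the saturated chain carbon bound to an amine nitrogen gives a number 3.55 log units higher from compound 2 to compound 4 (beyond the scatter) and hydrogen in place of ethyl, eight bonds along the chain from an amine nitrogen, gives a number 1.00 log units lower from compound 1 to compound 4 (beyond the scatter) in the opposite direction. Of these three single changes, only the heptyl step counts as large, while the chloro and ethyl steps are both modest.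

Nothing measured here accounts for the size of any of these steps. Going by these compounds, it also remains open whether a bromine or a methoxy group at the same place on the ring would give a step like the chloro one, and whether chloro would give the same step on a compound with a different chain.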